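The compounds below may be only part of what the source reports. "The series", "measured", "known", "first", "only" and "open" are said of these compounds alone.

Measured compounds:
compound 1 `O=C(NO)c1ccc(NCc2nc(-c3cccs3)nn2-c2ccc(O)cc2)cc1` — > 20000 nM
compound 2 `COc1ccc(-c2nc(CNc3ccc(C(=O)NO)cc3)n(-c3ccccc3)n2)cc1` — > 20000 nM
compound 3 `O=C(NO)c1ccc(NCc2nc(-c3ccccc3)nn2-c2ccccc2Cl)cc1` — 9630 nM

In a functional assay on MGC-803 cells (Homo sapiens) for antiproliferative activity, read by MTT assay, with a stated time of 72 h (a lower number here means a stronger inhibitor, a higher number a weaker inhibitor), compound 1 reaches only a limit, > 20000 nM. Compound 2 likewise reaches only a limit, > 20000 nM. For the measured compounds named here, compound 3 gives 9630 nM, the single number among the three, while the two others sit at the limit of > 20000 nM in this assay, at which 2 of the 3 values shown sit. Compound 4 `O=C(NO)c1ccc(NCc2nc(-c3ccccc3)nn2-c2cccc(Cl)c2)cc1` differs from compound 3 by 3-chlorophenyl in place of 2-chlorophenyl on an aromatic nitrogen. Going by the values given here, no step between measured compounds is available to size this change, so the expectation rests on compound 3 alone. The step from compound 3 to compound 4 is expected to stay within the scatter, a 1.1-fold lower number from compound 3 to compound 4 (0.03 log units; within the scatter). Compound 4 is therefore estimated at 9000 nM, between 4000 nM and 20000 nM.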

Compound 4, half-maximal inhibitory concentration: 13700 nM
Compound 4: the middle estimate sits 1.5-fold (0.18 log units) below what was measured, within the range that was stated.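

In this assay, replacing 2-chlorophenyl with 3-chlorophenyl on the aromatic nitrogen gives a 1.4-fold higher number from compound 3 to compound 4 (0.15 log units; within the scatter). For the compounds shown here, this is the only step that can be read at this position, and it shows that the two chlorophenyl groups cannot be told apart here. Compound 1 and compound 2 differ from these two in more than one place and give only a limit: the limit of > 20000 nM in this assay, at which 2 of the 4 values shown sit.

From the compounds shown here alone, what stays open is whether an amine or a carboxylic acid on this phenyl ring would move the number beyond the scatter. Going by these compounds, the effect of 4-chlorophenyl at this position also remains unknown.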